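Urea to amide on the shared core of compound 3

This account rests on a few compounds, and the source may have more. Where it says the series, first, only, none or still open, it means among the compounds named here.

Measured compounds in a functional assay on NCI-H226 cells (Homo sapiens) for inhibition, read by sulforhodamine B assay, with a stated time of 48 h, tested at 0.1 uM; on this read-out higher numbers stand for a weaker effect at the one concentration tested and lower numbers for a stronger effect:
compound 1 `O=C(Nc1cccc(-n2cc(-c3ccncc3)c(-c3cc(O)cc(Cl)c3)n2)c1)Nc1ccc(Cl)c(C(F)(F)F)c1` gives 95%
compound 2 `O=C(Nc1cccc(-n2cc(-c3ccncc3)c(-c3cc(O)cc(Cl)c3)n2)c1)Nc1ccc(Cl)c(Cl)c1` gives 89%
compound 3 `COc1cc(Cl)cc(-c2nn(-c3cccc(NC(=O)Nc4ccc(Cl)c(Cl)c4)c3)cc2-c2ccncc2)c1` gives 96%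

Compound 3 sits at the top of these three numbers, yet its gaps to compound 1 and to compound 2 are both within the scatter, so the three are indistinguishable. Compound 4 `COc1cc(Cl)cc(-c2nn(-c3cccc(NC(=O)c4cccc(C(F)(F)F)c4)c3)cc2-c2ccncc2)c1` is to be measured in this assay. Its change from compound 3 is 3-(trifluoromethyl)phenyl in place of (3,4-dichlorophenyl)amino on a carbonyl carbon. For the measured compounds named here, the measured steps were a number 6 percentage points lower from compound 1 to compound 2 (within the scatter) and a number 7 percentage points higher from compound 2 to compound 3 (within the scatter); neither touches the carbonyl carbon, so no step bears directly on this change, and every number so far is weak. Compound 4 is therefore expected to give 93%, between 78% and 105%, a step of a number 3 percentage points lower from compound 3 to compound 4 (within the scatter) that is expected to stay within the scatter.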

Compound 4, a percentage reported as activity, at one concentration (the size of the read-out at that concentration, not a potency): 90%
Compound 4: middle estimate off by 3 percentage points, on the high side; the measured number falls inside the stated range.
By their numbers in this assay, from the lowest: compounds 2, 4, 1 and 3 (each within the scatter of the next).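

In this assay, putting 3-(trifluoromethyl)phenyl in place of (3,4-dichlorophenyl)amino on the carbonyl carbon gives a number 6 percentage points lower from compound 3 to compound 4 (within the scatter), the first change shown at this position. The urea thus becomes an amide, and the hydrogen-bond donor of the leaving group goes with it, without moving the read-out beyond the scatter. No measurement at hand explains this result. Still open, going by these compounds, is whether a different group on this carbonyl carbon, such as an aliphatic amine, a carboxylic acid or a longer alkyl chain, would give a clearly stronger effect at this concentration.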